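Swapping chloro for methyl on compound 3

A few compounds are considered here, and "the series" means these few. Any claim that something is new, unique, unknown or untested is made for them only; others in the source may bear on it.

In a physicochemical assay for solubility, read by HPLC, in phosphate buffer, measured as thermodynamic solubility, with a stated time of 24 h, at pH 6.8 (a higher number here means a more soluble compound, a lower number a less soluble compound), the measured compounds give these values:
- compound 1 `C=CC(=O)N1CC[C@H](N2C(=O)N(Cc3ccccc3)Cc3cnc(Nc4ccc(N5CCN(C)CC5)cc4OC)nc32)C1` gives 107 ug/mL
- compound 2 `C=CC(=O)N1CC[C@H](N2C(=O)N(c3ccccc3)Cc3cnc(Nc4ccc(N5CCN(C)CC5)cc4)nc32)C1` gives 976 ug/mL
- compound 3 `C=CC(=O)N1CC[C@H](N2C(=O)N(c3ccccc3)Cc3cnc(Nc4ccc(N5CCN(C)CC5)c(Cl)c4)nc32)C1` gives 215 ug/mL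

Compound 3 (215 ug/mL) lies within the usual scatter of compound 1 (107 ug/mL), while its gap to compound 2 (976 ug/mL) goes beyond the scatter. The unmeasured compound 4 `C=CC(=O)N1CC[C@H](N2C(=O)N(c3ccccc3)Cc3cnc(Nc4ccc(N5CCN(C)CC5)c(C)c4)nc32)C1` carries a single change from compound 3, methyl in place of chloro on an aromatic carbon, ortho to a 4-methylpiperazin-1-yl group.

Within the data shown here, only one measured step bears on this spot, a 4.5-fold lower number from compound 2 to compound 3 (0.66 log units; beyond the scatter) when chloro takes the place of hydrogen. Compound 1 differs from compound 3 in more than one place, so it offers no clean comparison. Among the measured compounds shown here, no measured compound has methyl at this spot, so the size of this swap can only be judged loosely. The chloro step is a modest one, and a step of that size is not expected here, since hydrogen is not what enters. What is expected in this assay is a 1.4-fold higher number from compound 3 to compound 4 (0.14 log units; within the scatter) and thus nothing beyond the scatter, with only a slight lean upward. The estimate for compound 4 is 300 ug/mL (expected range 130 ug/mL to 650 ug/mL).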

Compound 4, solubility: 1270 ug/mL
Compound 4: the middle estimate sits 4.2-fold (0.63 log units) below what was measured; measured number outside the range, above it.
By their numbers in this assay, from the lowest: compounds 1 and 3 (each within the scatter of the next); then compounds 2 and 4 (each within the scatter of the next).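

In this assay, putting methyl in place of chloro on the aromatic carbon ortho to a 4-methylpiperazin-1-yl group gives a 5.9-fold higher number from compound 3 to compound 4 (0.77 log units; beyond the scatter), so two groups of one heavy atom each, with no ring, no charge and no hydrogen-bond donors or acceptors by count, are far from interchangeable at this position. Comparing methyl with hydrogen on the same carbon gives a 1.3-fold higher number from compound 2 to compound 4 (0.11 log units; within the scatter), which means the two cannot be told apart in this measurement. Compound 2 and compound 4 therefore sit together, and among hydrogen, chloro and methyl on this carbon, only chloro goes with the lower number, as the earlier step of a 4.5-fold lower number from compound 2 to compound 3 (0.66 log units; beyond the scatter) had shown without a second group to compare.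

Nothing shown here explains why chloro and methyl differ so much at this position. As far as these compounds go, it also remains open whether fluoro, methoxy or a longer chain such as ethyl on this carbon would fall with chloro or with methyl and hydrogen.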